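The compounds below may be only part of what the source reports. "The series", "measured", "known", "first", "only" and "open" are said of these compounds alone.

Compound 1, `CCOC(=O)C1=C(C)NC(C)=C(C(=O)OCC)C1c1csc(-c2ccc(Cl)cc2)n1`: 3650 nM
Compound 2, `CCOC(=O)C1=C(C)NC(C)=C(C(=O)OC)C1c1csc(-c2ccc(Cl)cc2)n1`: 22000 nM
Compound 3, `CCCOC(=O)C1=C(C)NC(C)=C(C(=O)OC)C1c1csc(-c2ccc(Cl)cc2)n1`: 5920 nM

All three were measured in an assay on isolated protein for antagonist activity at Voltage-dependent L-type calcium channel subunit alpha-1C (Cavia porcellus), with a stated time of 15 min; a higher number here means a weaker inhibitor, a lower number a stronger inhibitor. Compound 3 stands second highest of the three numbers: its value sits close to that of compound 1, within the usual scatter, while it lies clearly below compound 2, as the step of a 3.7-fold lower number from compound 2 to compound 3 (0.57 log units; beyond the scatter) shows. Compound 4, `CCCOC(=O)C1=C(C)NC(C)=C(C(=O)OCC)C1c1csc(-c2ccc(Cl)cc2)n1`, differs from compound 3 by methyl in place of hydrogen on a saturated chain carbon bound to an oxygen next to a carbonyl group. The measured step of a 6.0-fold higher number from compound 1 to compound 2 (0.78 log units; beyond the scatter) is the same change run backwards, and it shifted the number by a modest amount. Adding the methyl is therefore expected to lower the number by a similar, modest step, a 5.9-fold lower number from compound 3 to compound 4 (0.77 log units; beyond the scatter). Compound 4 is thus estimated at 1000 nM, with a range from 400 nM to 2500 nM.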

Compound 4, half-maximal inhibitory concentration: 4090 nM
Compound 4: the middle estimate sits 4.1-fold (0.61 log units) below what was measured, outside the stated range (above it).
By their numbers in this assay, from the lowest: compounds 1, 4 and 3 (each within the scatter of the next); then compound 2.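

Adding the methyl on a saturated chain carbon bound to an oxygen next to a carbonyl group is not a constant step, for here it gives only a 1.4-fold lower number from compound 3 to compound 4 (0.16 log units; within the scatter), much less than on the other core: the same change on two cores in this assay, a 6.0-fold higher number (0.78 log units; beyond the scatter) from compound 1 to compound 2 and a 1.4-fold higher number (0.16 log units; within the scatter) from compound 4 to compound 3, 4.2-fold (0.62 log units) apart, beyond the scatter of two such steps. The methyl two bonds along the chain behaves the same way, giving a 1.1-fold higher number from compound 1 to compound 4 (0.05 log units; within the scatter), so the two changes do not add up: the same change on two cores in this assay, a 3.7-fold lower number (0.57 log units; beyond the scatter) from compound 2 to compound 3 and a 1.1-fold higher number (0.05 log units; within the scatter) from compound 1 to compound 4, 4.2-fold (0.62 log units) apart, beyond the scatter of two such steps. Either change alone closes the gap, and making both gives a 5.4-fold lower number from compound 2 to compound 4 (0.73 log units; beyond the scatter).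

A butyl chain or a chain ending in an amine could show whether the number stays level or shifts again.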